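Phenoxy in Place of tert-Butylamino on a Shared Core

The compounds below may be only part of what the source reports. "The series", "measured", "known", "first", "only" and "open" are said of these compounds alone.

Compound 1 `CC(C)(C)Nc1nc(N)c(C(=O)N=C(N)N)nc1Cl`: "not determined" (no result reported)
Compound 2 `NC(N)=NC(=O)c1nc(Cl)c(NCc2cccc(F)c2)nc1N`: 29%
Compound 3 `NC(N)=NC(=O)c1nc(Cl)c(Nc2cnc3ccccc3c2)nc1N`: 28%

Three compounds on one core have been examined in an assay for inhibition of acid-sensing ion channel 3 (Homo sapiens), read by patch clamp, tested at 1 uM; on this read-out higher numbers stand for more inhibition at the one concentration tested (going by the name of the read-out) and lower numbers for less inhibition. Compound 1 was tested but yields no result in this assay, so it stands nowhere on the numbers shown. In this assay compound 2 gives 29% and compound 3 gives 28%; these two values lie within the usual scatter of each other, so nothing separates them.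

Compound 4 `NC(N)=NC(=O)c1nc(Cl)c(Oc2ccccc2)nc1N` has not yet been measured. It differs from compound 1 in one place: phenoxy in place of (tert-butyl)amino on an aromatic carbon. Going by the values given here, since compound 1 itself has no number, no step in this assay can be laid down from it, and none between the measured compounds is at hand either. Among the compounds with values here, the two measured values, both moderate, are the only guide. Compound 4 is therefore expected to show inhibition of a similar moderate size, estimated at 27%, with a range from 5% to 50%.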

Compound 4, a percentage reported as inhibition, at one concentration (the size of the read-out at that concentration, not a potency): 23%
Beside the measured number, compound 4's estimate is 4 percentage points above it; low and high end bracket the measured number.
By their numbers in this assay, from the lowest: compounds 4, 3 and 2 (each within the scatter of the next).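

In this assay compound 1 gives "not determined" (no result reported) and compound 4 gives 23%, so no step can be read between them. No evidence bears on this result. The compounds shown leave open how phenoxy compares with (tert-butyl)amino on the shared core.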